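Fluoro for Methyl on the Phenoxy Ring

This account rests on a few compounds, and the source may have more. Where it says the series, first, only, none or still open, it means among the compounds named here.

The series shares one core: compound 1 `S=C(N/N=C/c1ccc(Oc2ccc(Cl)cc2)cc1)Nc1ccccc1`, compound 2 `Fc1ccc(Oc2ccc(/C=N/NC(=S)Nc3ccc(Cl)cc3)cc2)cc1` and compound 3 `Cc1ccc(Oc2ccc(/C=N/NC(=S)Nc3ccccc3)cc2)cc1`, each bearing a different substituent on the outer aromatic ring. In a physicochemical assay for lipophilicity, in phosphate buffer, measured as octanol-water partition, with a stated time of 24 h (on this read-out lower numbers stand for lower lipophilicity and higher numbers for higher lipophilicity), compound 1 gives 5.52, compound 2 gives 5.84 and compound 3 gives 5.39. Compound 3 therefore holds the lowest of the three numbers, though its nearest neighbour, compound 1, differs from it only within the scatter, while compound 2 lies beyond the scatter above it.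

The next compound, compound 4 `Fc1ccc(Oc2ccc(/C=N/NC(=S)Nc3ccccc3)cc2)cc1`, is reached from compound 3 by a single change: fluoro in place of methyl on an aromatic carbon. Among the compounds with values here, no measured pair shows exactly this exchange. Within the data shown here, the only step at the same place is a number 0.13 log units lower from compound 1 to compound 3 (within the scatter), which shows that swapping one small substituent for another on this ring moved the partition coefficient little. Compound 2 also carries a fluoro at this position, but it differs from compound 4 in a second place as well, so its value can only be read alongside that of compound 1 without being assigned to one change.

On this basis compound 4 is expected to sit modestly below compound 3, a step of a number 0.24 log units lower from compound 3 to compound 4 (within the scatter) in this assay. The estimate for compound 4 is 5.15, with a range from 4.8 to 5.5.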

Compound 4, partition coefficient: 5.09
Compound 4: the middle estimate sits 0.06 log units above what was measured, within the range that was stated.
By their numbers in this assay, from the lowest: compounds 4, 3 and 1 (each within the scatter of the next, the first and the last beyond it); then compound 2.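

Within the data shown here, with compound 4 in hand, the position para to a large group can be read across three substituents in this assay and two of its steps now sit side by side, with fluoro in place of methyl giving a number 0.30 log units lower from compound 3 to compound 4 (within the scatter) and fluoro in place of chloro giving a number 0.43 log units lower from compound 1 to compound 4 (beyond the scatter) as the first step at this place to pass beyond the scatter. Read with a number 0.13 log units lower from compound 1 to compound 3 (within the scatter) as the third side of the set, these steps leave methyl within the scatter of both chloro and fluoro, so that only chloro and fluoro are separated from each other here. Compound 4 also opens a reading of a second place on the molecule, where dropping the chloro gives a number 0.75 log units lower from compound 2 to compound 4 (beyond the scatter) on its own, though nothing available here accounts for the size of any of these steps.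

Going by these compounds, it remains open how other groups at the first position, such as an amine, a carboxylic acid or a methoxy group, would read in this assay against these three. Also open, on these data alone, is whether the step from chloro to hydrogen at the second place keeps its size with methyl or chloro in place of fluoro at the first.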